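Second trifluoromethyl on the urea aryl of compound 1

The compounds below may be only part of what the source reports. "The series", "measured", "known", "first", "only" and "open" are said of these compounds alone.

Compound 1 `O=C(Nc1cccc(-n2cc(-c3ccncc3)c(-c3ccc(Cl)c(O)c3)n2)c1)Nc1cccc(C(F)(F)F)c1` is assessed in a functional assay on OVCAR-8 cells (Homo sapiens) for inhibition, read by sulforhodamine B assay, with a stated time of 48 h; a lower number here means that less compound is tolerated, a higher number that more compound is tolerated. Compound 1 gives > 32500 nM, which is a limit of the assay and not a number. Compound 2 `O=C(Nc1cccc(-n2cc(-c3ccncc3)c(-c3ccc(Cl)c(O)c3)n2)c1)Nc1ccc(Cl)c(Cl)c1` gives > 32500 nM, likewise a limit. Compound 3 `COc1cc(-c2nn(-c3cccc(NC(=O)Nc4cccc(C(F)(F)F)c4)c3)cc2-c2ccncc2)ccc1Cl` gives > 50000 nM, also a limit. The steps a step that the two limits leave unreadable from compound 1 to compound 2 and a step that the two limits leave unreadable from compound 1 to compound 3 are accordingly unreadable; all three values sit at the limit of > 32500 nM in this assay, at which 2 of the 3 values shown sit, or (the limit of > 50000 nM in this assay, at which 1 of the 3 values shown sits). Compound 4 `O=C(Nc1cccc(-n2cc(-c3ccncc3)c(-c3ccc(Cl)c(O)c3)n2)c1)Nc1cc(C(F)(F)F)cc(C(F)(F)F)c1` differs from compound 1 by trifluoromethyl in place of hydrogen on an aromatic carbon. Neither measured step reads on this change, so no direction beyond the scatter can be taken from them for this assay; compound 1 stands at a limit and the expectation is that compound 4 remains there. The expected step is a step that the limit leaves unreadable from compound 1 to compound 4. Compound 4 is estimated at 40000 nM, within 20000 nM to 100000 nM.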

Compound 4, concentration lethal to 50% of the cells: 43700 nM
Beside the measured number, compound 4's estimate is 1.1-fold (0.04 log units) below it, and the stated range covers the measured number.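

Compound 1 stands only at a limit of the assay, so its step to compound 4 cannot be read. The compounds shown leave open whether trifluoromethyl in place of hydrogen on an aromatic carbon shifts the lethal concentration at all.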